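Amide for Hydroxyethyl on the Side Chain at TLR8

This account rests on a few compounds, and the source may have more. Where it says the series, first, only, none or still open, it means among the compounds named here.

Working notes on the series. Compound 1 `CCCC[C@H](CCO)Nc1nc(N)nc2cccnc12` carries a 2-hydroxyethyl group on the saturated chain carbon bound to a nitrogen on an aromatic ring. In an assay on tissue (PBMC cells) for agonist activity at Toll-like receptor 8 (Homo sapiens), with a stated time of 24 h (on this read-out lower numbers stand for an effect already at smaller amounts and higher numbers for an effect only at larger amounts of compound), compound 1 gives 4300 nM. Going by the values given here, compound 2 `CCCCC[C@H](CO)Nc1nc(N)nc2cccnc12` gives 3330 nM in this assay; the two numbers lie within the scatter of each other, so compound 1 cannot be separated from compound 2 on this read-out, and no measured pair in the set shows any structural step of known size.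

Compound 3 `CCCC[C@@H](Nc1nc(N)nc2cccnc12)C(N)=O` differs from compound 1 by carbamoyl in place of 2-hydroxyethyl on a saturated chain carbon bound to a nitrogen on an aromatic ring and a saturated chain carbon. Among the compounds with values here, no measured pair shows this exchange, so its size must be guessed; with nothing in the data pointing either way, a step of no more than the usual scatter, in either direction, is expected. Compound 3 is estimated at 3000 nM in this assay, with a range from 800 nM to 12000 nM. The expected step of a 1.4-fold lower number from compound 1 to compound 3 (0.16 log units; within the scatter) is therefore small and carries a wide uncertainty.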

Compound 3, half-maximal effective concentration: 36000 nM
For compound 3 the middle estimate is 12-fold (1.08 log units) below the measured one, outside the stated range (above it).
By their numbers in this assay, from the lowest: compounds 2 and 1 (each within the scatter of the next); then compound 3.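

In this assay, going by these compounds alone, this position responds to the exchange of carbamoyl for 2-hydroxyethyl, with an 8.4-fold higher number from compound 1 to compound 3 (0.92 log units; beyond the scatter) as the first step in the set beyond the scatter. The two groups match in 3 heavy atoms, 1 hydrogen-bond donor, 1 hydrogen-bond acceptor, no ring and no net charge, so the step arises without any change in those counts; what differs is a nitrogen in the entering group and its 1 double bond outside aromatic rings. Nothing available bears on why the number rises.

From the compounds shown here alone, whether a carboxylic acid, an amine or a longer chain at this place would give a number nearer that of compound 1 or that of compound 3 remains open. Also open, going by these compounds, is whether the same exchange on the chain of compound 2 would give a step of similar size.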